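A few compounds are considered here, and "the series" means these few. Any claim that something is new, unique, unknown or untested is made for them only; others in the source may bear on it.

Measured so far in a functional assay on CHO cells with adenosine receptor A1 (Homo sapiens) as the target, read by cAMP accumulation and immunoassay, with a stated time of 6 min, tested at 1 uM; a lower number here means a stronger effect, a higher number a weaker effect of the compound at the concentration tested:
compound 1 `Nc1scc(CN2CCN(c3ccc([N+](=O)[O-])cc3)CC2)c1C(=O)c1ccc(Cl)cc1` — -8.3%
compound 2 `Nc1scc(CN2CCN(c3cc(F)cc(F)c3)CC2)c1C(=O)c1ccc(Cl)cc1` — -66%

Among the compounds with values here, compound 1 stands highest of the two numbers; its nearest neighbour is compound 2, and the single step between them, a number 57.7 percentage points lower from compound 1 to compound 2 (beyond the scatter), is large and beyond the scatter.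

Compound 3 `Nc1scc(CN2CCN(c3c(F)cc(F)cc3F)CC2)c1C(=O)c1ccc(Cl)cc1` is not yet measured. It differs from compound 1 in one place: 2,4,6-trifluorophenyl in place of 4-nitrophenyl on an amine nitrogen in a ring.

Within the data shown here, the only step that bears on this change is the one from compound 1 to compound 2, where a fluorinated phenyl also replaced the 4-nitrophenyl on the amine nitrogen in the ring and the number fell by a number 57.7 percentage points lower from compound 1 to compound 2 (beyond the scatter). The 2,4,6-trifluorophenyl of compound 3 is not the same group as the 3,5-difluorophenyl of compound 2, so the size carries over only loosely; a drop of similar direction is expected, with wide uncertainty.

Compound 3 is therefore expected to give -45%, within -80% to -5%, an estimated step of a number 36.7 percentage points lower from compound 1 to compound 3 (beyond the scatter).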

Compound 3, a percentage reported as activity, at one concentration (the size of the read-out at that concentration, not a potency): -56%
For compound 3 the middle estimate is 11 percentage points above the measured one; low and high end bracket the measured number.
By their numbers in this assay, from the lowest: compounds 2 and 3 (each within the scatter of the next); then compound 1.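

In this assay, the large fall seen on leaving 4-nitrophenyl recurs with a second fluorinated phenyl on the amine nitrogen in the ring, a number 47.7 percentage points lower from compound 1 to compound 3 (beyond the scatter), so it is not confined to the 3,5-difluorophenyl of compound 2. The change of fluorine pattern does not separate the two fluorinated compounds, with a number 10 percentage points higher from compound 2 to compound 3 (within the scatter), and 2,4,6-trifluorophenyl fits this position as well as 3,5-difluorophenyl within what the assay can resolve.

Going by these compounds, it remains open whether fluorine is needed at all, or whether the departure of 4-nitrophenyl alone accounts for the fall; an unsubstituted phenyl, a 4-methoxyphenyl or a 2-pyridyl on the same nitrogen would address this. On these data alone, the effect of a single fluorine also remains open, as does any change to the 4-chlorophenyl ketone of the shared core. No measurement at hand gives a reason for either step.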